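This account rests on a few compounds, and the source may have more. Where it says the series, first, only, none or still open, it means among the compounds named here.

Series notes. In an ADME assay on MT4 cells (Homo sapiens) for cytotoxicity, read by MTT assay, with a stated time of 4 days (on this read-out higher numbers stand for lower toxicity in this test and lower numbers for higher toxicity in this test), compound 1 `N#Cc1ccc(Nc2nc(Oc3c(Cl)cc(Cl)cc3Cl)c3ccccc3n2)cc1` gives 56000 nM, compound 2 `N#Cc1ccc(Nc2nc(Oc3ccc(Cl)cc3)c3ccccc3n2)cc1` gives 198000 nM and compound 3 `N#Cc1ccc(Nc2nc(Oc3ccc(Br)cc3)c3ccccc3n2)cc1` gives 215000 nM. Compound 3 holds the highest number of the three, but its gap to compound 2 is within the scatter a 1.1-fold higher number from compound 2 to compound 3 (0.04 log units; within the scatter), so the two are not separated; only compound 1 stands apart, with the steps of a 3.5-fold higher number from compound 1 to compound 2 (0.55 log units; beyond the scatter) and a 3.8-fold higher number from compound 1 to compound 3 (0.58 log units; beyond the scatter) both beyond the scatter.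

Compound 4 `Cc1cc(Br)cc(Br)c1Oc1nc(Nc2ccc(C#N)cc2)nc2ccccc12` differs from compound 3 in one place: 2,4-dibromo-6-methylphenyl in place of 4-bromophenyl on an oxygen on an aromatic ring. For the measured compounds named here, the steps that bear on this are the two from compound 1, where 2,4,6-trichlorophenyl gave way to 4-chlorophenyl or 4-bromophenyl and the number rose by a modest amount. The change to compound 4 runs the other way, from 4-bromophenyl back to a ring carrying three substituents, 2,4-dibromo-6-methylphenyl, so a drop of about the same modest size is expected in this assay, with the number of compound 4 expected to land near that of compound 1. Compound 4 is therefore estimated at 60000 nM, in the range 25000 nM to 150000 nM, the expected step being a 3.6-fold lower number from compound 3 to compound 4 (0.55 log units; beyond the scatter).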

Compound 4, half-maximal cytotoxic concentration: 150000 nM
For compound 4 the middle estimate is 2.5-fold (0.40 log units) below the measured one; measured number inside the range.
By their numbers in this assay, from the lowest: compound 1; then compounds 4, 2 and 3 (each within the scatter of the next).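

In this assay, the step to 2,4-dibromo-6-methylphenyl gives a 1.4-fold lower number from compound 3 to compound 4 (0.16 log units; within the scatter) and a 1.3-fold lower number from compound 2 to compound 4 (0.12 log units; within the scatter), so this more heavily substituted group on the oxygen is not separated from 4-bromophenyl or 4-chlorophenyl. The step of a 2.7-fold higher number from compound 1 to compound 4 (0.43 log units; beyond the scatter) separates it from 2,4,6-trichlorophenyl, so the low number of compound 1 does not extend to every more heavily substituted ring at this position, and compound 4 is the case against such a pattern. Nothing shown gives a reason for the difference between these two groups.

From the compounds shown here alone, compound 4 differs from compound 1 in both halogen and methyl at once, so it remains open which of these changes matters. Also open, going by these compounds, is how a ring carrying an amine or a carboxylic acid at this position would read in this assay.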